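Benzyl amide to 1-phenylethyl amide: working notes

This account rests on a few compounds, and the source may have more. Where it says the series, first, only, none or still open, it means among the compounds named here.

compound 1 `CCCCc1oc2ccccc2c1C(=O)c1ccc(OCCCC(=O)N2CCCCC2)cc1`: 31900 nM
compound 2 `CCCCc1oc2ccccc2c1C(=O)c1ccc(OCCCC(=O)NCc2ccccc2)cc1`: 28900 nM

Among the measured compounds shown here, only two compounds have been measured so far in a functional assay on HL-60 cells (Homo sapiens) for antiproliferative activity, read by MTT assay, with a stated time of 24 h (on this read-out higher numbers stand for weaker inhibition and lower numbers for stronger inhibition), and compound 2 at 28900 nM sits level with compound 1, within the scatter. The next compound is compound 3 `CCCCc1oc2ccccc2c1C(=O)c1ccc(OCCCC(=O)N[C@H](C)c2ccccc2)cc1`, and the change is methyl in place of hydrogen on a saturated chain carbon bound to an amide-type nitrogen and an aromatic carbon. Benzylamino thus becomes (1-phenylethyl)amino. For the measured compounds named here, only one measured step bears on this, and only indirectly: a 1.1-fold lower number from compound 1 to compound 2 (0.04 log units; within the scatter). That step also altered the group on the carbonyl carbon, but a much larger exchange left the number within the scatter. Going by the values given here, no measured step adds a methyl, so the data give no direction, and no step beyond the scatter is expected in this assay. The expected step is a 1.1-fold lower number from compound 2 to compound 3 (0.03 log units; within the scatter). For compound 3 the estimated value is 27000 nM, with an expected range of 12000 nM to 55000 nM.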

Compound 3, half-maximal inhibitory concentration: > 50000 nM
Compound 3: a limit, no number; the forecaster's own chance of this, stated with the estimate: 10%; at least 1.8-fold (0.26 log units) between middle value and limit.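

In this assay compound 3 stands at a limit of the assay and not at a number: the limit of > 50000 nM in this assay, at which 1 of the 3 values shown sits.

Adding methyl on the saturated chain carbon bound to the amide-type nitrogen and the aromatic carbon gives an at least 1.7-fold higher number from compound 2 to compound 3 (0.23 log units; that floor lies within the scatter), and replacing piperidin-1-yl on the carbonyl carbon with (1-phenylethyl)amino gives an at least 1.5-fold higher number from compound 1 to compound 3 (0.19 log units; that floor lies within the scatter). Among the compounds shown here, compound 1 and compound 2 sit level, so compound 3 is the first to leave the measurable range, though neither floor shows a step beyond the scatter and the true size of both steps remains unknown.

Going by these compounds, whether the mirror-image 1-phenylethyl amide behaves the same way remains open. So does the outcome with an ethyl group in place of the methyl at this carbon.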